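Cyano in Place of Chloro: Expected Cytotoxicity of Compound 3

This account rests on a few compounds, and the source may have more. Where it says the series, first, only, none or still open, it means among the compounds named here.

For the measured compounds named here, compound 1 `COc1ncnc(Nc2ccc(Cl)c(OCC=C(C)C)c2)n1` gives 18000 nM in an ADME assay on MT2 cells (Homo sapiens) for cytotoxicity (a higher number here means that more compound is tolerated, a lower number that less compound is tolerated), one of only two numbers measured so far. Compound 2 `COc1nc(Cl)nc(Nc2ccc(Cl)c(OCC=C(C)C)c2)n1` gives 26000 nM, and the step of a 1.4-fold higher number from compound 1 to compound 2 (0.16 log units; within the scatter) lies within the scatter. Compound 3 `COc1ncnc(Nc2ccc(C#N)c(OCC=C(C)C)c2)n1` differs from compound 1 by cyano in place of chloro on an aromatic carbon. Going by the values given here, no measured step covers this exchange; the single measured step, chloro in place of hydrogen on an aromatic carbon, stayed within the scatter. Compound 3 is therefore expected to stay close to its parent, no change at the digits printed from compound 1 to compound 3 (within the scatter), with an estimated 18000 nM and a range from 8000 nM to 40000 nM.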

Compound 3, half-maximal cytotoxic concentration: 42000 nM
For compound 3 the middle estimate is 2.3-fold (0.37 log units) below the measured one, outside the stated range (above it).
By their numbers in this assay, from the lowest: compounds 1, 2 and 3 (each within the scatter of the next, the first and the last beyond it).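

In this assay, cyano in place of chloro on the aromatic carbon ortho to the (3-methylbut-2-en-1-yl)oxy group gives a 2.3-fold higher number from compound 1 to compound 3 (0.37 log units; beyond the scatter), so this position responds to a change of group. The earlier step, a 1.4-fold higher number from compound 1 to compound 2 (0.16 log units; within the scatter), concerned a different place and did not show this. Nothing available accounts for the shift. For the compounds shown here, with only one exchange at this position, it remains open whether the shift is particular to cyano. From the compounds shown here alone, how an amine or a carboxylic acid on this carbon would compare also remains open.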